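Replacing 4-fluorophenyl with pyridin-4-yl: what to expect

The source may hold more compounds than are shown below. What is called first, only, known or untested is meant among the compounds shown, and "the series" means these compounds.

Measured in a functional assay on HeLa cells (Homo sapiens) for cytotoxicity, read by WST assay, with a stated time of 48 h; on this read-out higher numbers stand for weaker inhibition and lower numbers for stronger inhibition:
compound 1 `O[C@@H](c1ccccc1)[C@H]1CO[C@H](c2ccccc2)[C@@H](C/C=C/c2ccccc2)C1` gives 6060 nM
compound 2 `Oc1ccc(/C=C/C[C@H]2C[C@@H]([C@@H](O)c3ccccc3)CO[C@@H]2c2ccccc2)cc1` gives 14400 nM
compound 3 `O[C@@H](c1ccccc1)[C@H]1CO[C@H](c2ccccc2)[C@@H](C/C=C/c2ccc(F)cc2)C1` gives 8340 nM

Compound 3 stands within the scatter of both other compounds, as shown by a 1.4-fold higher number from compound 1 to compound 3 (0.14 log units; within the scatter) and by a 1.7-fold lower number from compound 2 to compound 3 (0.24 log units; within the scatter). Compound 4 `O[C@@H](c1ccccc1)[C@H]1CO[C@H](c2ccccc2)[C@@H](C/C=C/c2ccncc2)C1` differs from it in one place: pyridin-4-yl in place of 4-fluorophenyl on a double-bonded chain carbon bound to a double-bonded chain carbon, with pyridin-4-yl in place of 4-fluorophenyl on a double-bonded chain carbon bound to a double-bonded chain carbon. Going by the values given here, no measured step makes this exact swap, so the evidence is indirect. Among the compounds with values here, the fluoro step stayed within the scatter, and the only step beyond it, a 2.4-fold higher number from compound 1 to compound 2 (0.38 log units; beyond the scatter), is modest. A small move toward a higher number, or none beyond the scatter, is therefore expected in this assay. The expected step is a 1.3-fold higher number from compound 3 to compound 4 (0.12 log units; within the scatter) and no larger trend can be claimed. For compound 4 the estimated value is 11000 nM, within an expected range of 5000 nM to 25000 nM.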

Compound 4, half-maximal inhibitory concentration: > 100000 nM
Compound 4: no number, only a limit; the forecaster's own chance of this, stated with the estimate: 10%; at least 9.0-fold (0.95 log units) between middle value and limit.
By their numbers in this assay, from the lowest: compounds 1, 3 and 2 (each within the scatter of the next, the first and the last beyond it). At a limit, above all of these: compound 4.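

In this assay compound 4 gives a limit and not a number: the limit of > 100000 nM in this assay, at which 1 of the 4 values shown sits.
Against an at least 11-fold higher number from compound 3 to compound 4 (1.07 log units; beyond the scatter) and an at least 16-fold higher number from compound 1 to compound 4 (1.21 log units; beyond the scatter) and an at least 6.9-fold higher number from compound 2 to compound 4 (0.84 log units; beyond the scatter) the earlier changes on this aromatic ring look small. Among these compounds, then, this place on the chain responds far more to swapping the ring for pyridin-4-yl than to adding hydroxy or fluoro to the phenyl ring.

Still open, on these data alone, is how a pyrimidine ring would behave here, or an amine in place of the fluoro. The compounds shown also give no reason for the large step.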